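Adding a methyl group to a weak amide

The source may report more compounds than this note shows. Statements on the series, on what has been measured and on what is new or still open speak of the compounds shown alone.

In a functional assay on SiHa cells (Homo sapiens) for antiproliferative activity, read by CCK-8 assay, with a stated time of 72 h (on this read-out lower numbers stand for stronger inhibition and higher numbers for weaker inhibition), compound 1 `COc1ccc(-c2cncnc2-c2cc(OC)c(OC)c(OC)c2)cc1` gives 2850 nM, and compound 2 `COc1cc(-c2ncncc2-c2ccc(OC(C)C)cc2)cc(OC)c1OC` gives 9970 nM. Compound 3 `COc1cc(-c2ncncc2-c2ccc(C(N)=O)cc2)cc(OC)c1OC` gives > 100000 nM, which is a limit of the assay and not a number. On these data alone, that places compound 3 at the limit of > 100000 nM in this assay, at which 1 of the 3 values shown sits, so its true value stays unknown. Compound 4 `CNC(=O)c1ccc(-c2cncnc2-c2cc(OC)c(OC)c(OC)c2)cc1` has not yet been measured. It differs from compound 3 by methyl in place of hydrogen on an amide-type nitrogen, turning carbamoyl into methylcarbamoyl.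

Two large changes bear on this, the steps that introduced the carbamoyl: an at least 35-fold higher number from compound 1 to compound 3 (1.54 log units; beyond the scatter) and an at least 10-fold higher number from compound 2 to compound 3 (1.00 log units; beyond the scatter). Compound 4 keeps that amide, so it is expected to stay weak. Among the compounds with values here, the one step that enlarges a small alkyl group, a 3.5-fold higher number from compound 1 to compound 2 (0.54 log units; beyond the scatter), was modest. Only a modest move toward a lower number is therefore expected in this assay, and the limit on compound 3 blurs its size. The estimated step is an at least 2.2-fold lower number from compound 3 to compound 4 (0.34 log units; beyond the scatter). The expected value for compound 4 is 45000 nM, with a range from 12000 nM to 100000 nM.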

Compound 4, half-maximal inhibitory concentration: 10900 nM
Compound 4: middle estimate off by 4.1-fold (0.62 log units), on the high side; measured number outside the range, below it.
By their numbers in this assay, from the lowest: compound 1; then compounds 2 and 4 (each within the scatter of the next). At a limit, above all of these: compound 3.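

In this assay, a single methyl on the amide-type nitrogen is enough to bring the amide back to a measurable number: an at least 9.1-fold lower number from compound 3 to compound 4 (0.96 log units; beyond the scatter). The true size of this step stays unknown, as the value of compound 3 is a limit: the limit of > 100000 nM in this assay, at which 1 of the 4 values shown sits.

Methylcarbamoyl cannot be told apart from isopropoxy on this aromatic carbon, with a 1.1-fold higher number from compound 2 to compound 4 (0.04 log units; within the scatter), although methoxy keeps an edge, with a 3.8-fold higher number from compound 1 to compound 4 (0.58 log units; beyond the scatter), so an amide here need not lose nearly all activity.

On these data alone, whether a second methyl or a longer chain such as ethyl or propyl on the same nitrogen would lower the number further remains open. So does the effect of an amine or a carboxylic acid on this aromatic carbon, and the compounds shown give no cause for the effect of the methyl.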